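Chloro in place of hydrogen on the core of compound 1

The source may report more compounds than this note shows. Statements on the series, on what has been measured and on what is new or still open speak of the compounds shown alone.

Compound 1 `CN1C(=O)C2(C(C#N)=C(N)Oc3cc4oc(-c5ccccc5)cc(=O)c4c(O)c32)c2ccccc21` gives in a functional assay on NCI-H1299 cells (Homo sapiens) for antiproliferative activity, read by MTT assay, with a stated time of 48 h (a lower number here means a stronger inhibitor, a higher number a weaker inhibitor), only a limit of the assay, > 50000 nM. Compound 2 `Cc1ccc2c(c1)C1(C(=O)N2C)C(C#N)=C(N)Oc2cc3oc(-c4ccccc4)cc(=O)c3c(O)c21` carries methyl in place of hydrogen on an aromatic carbon and in this assay gives 10200 nM; the step of an at least 4.9-fold lower number from compound 1 to compound 2 (0.69 log units; beyond the scatter) is the only measured one in the series. Compound 3 `CN1C(=O)C2(C(C#N)=C(N)Oc3cc4oc(-c5ccccc5)cc(=O)c4c(O)c32)c2cccc(Cl)c21` differs from compound 1 by chloro in place of hydrogen on an aromatic carbon. The methyl step bears only loosely on this change, since it concerns methyl rather than chloro, so a gain of similar or somewhat smaller size is expected: an at least 2.5-fold lower number from compound 1 to compound 3 (0.39 log units; beyond the scatter). For compound 3 the estimate is 20000 nM, between 6000 nM and 60000 nM.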

Compound 3, half-maximal inhibitory concentration: > 50000 nM
Compound 3: a limit, no number (the forecaster's own chance of this, stated with the estimate: 35%); middle value at least 2.5-fold (0.39 log units) from the limit.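

No step can be read from compound 1 to compound 3 in this assay, because both give only a limit of the assay: the limit of > 50000 nM in this assay, at which 2 of the 3 values shown sit.

On these data alone, whether chloro in place of hydrogen on an aromatic carbon changes the antiproliferative activity stays open.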